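A few compounds are considered here, and "the series" means these few. Any claim that something is new, unique, unknown or untested is made for them only; others in the source may bear on it.

Three compounds were measured in a functional assay on RKO cells (Homo sapiens) for cytotoxicity, read by resazurin assay, with a stated time of 72 h; a lower number here means a stronger inhibitor, a higher number a weaker inhibitor:

Compound 1 `COc1ccc(Nc2nc(-n3ccnc3C)cs2)cc1`: 1600 nM
Compound 2 `Cc1nc2ccccc2n1-c1csc(Nc2ccc(Br)cc2)n1`: 90 nM
Compound 3 `Cc1nccn1-c1csc(Nc2ccc(Br)cc2)n1`: 30000 nM

Compound 2 gives the lowest of the three numbers. The difference between the core of compound 2 and the core of compound 3 is not broken down here. Between compound 3 and compound 1 the change is methoxy in place of bromo on an aromatic carbon, and it gave a 19-fold lower number from compound 3 to compound 1 (1.27 log units; beyond the scatter).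

Compound 4 `COc1ccc(Nc2nc(-n3c(C)nc4ccccc43)cs2)cc1` has not been measured. It differs from compound 2 by methoxy in place of bromo on an aromatic carbon, the same change as from compound 3 to compound 1, at the same place. Resting on compound 3 and compound 1, whose step was a 19-fold lower number from compound 3 to compound 1 (1.27 log units; beyond the scatter), the step from compound 2 is expected to be a 6.0-fold lower number from compound 2 to compound 4 (0.78 log units; beyond the scatter), somewhat smaller because compound 2 already gives 90 nM. Compound 4 is therefore estimated at 15 nM, between 3 nM and 80 nM.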

Compound 4, half-maximal inhibitory concentration: 25 nM
Estimate against measurement, compound 4: 1.7-fold (0.22 log units) below; the measured number falls inside the stated range.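

The change from 4-bromophenyl to 4-methoxyphenyl gave a 3.6-fold lower number from compound 2 to compound 4 (0.56 log units; beyond the scatter) in this assay. The direction of the step carried over from one core to the other, but its size did not: the same change on two cores in this assay, a 19-fold lower number (1.27 log units; beyond the scatter) from compound 3 to compound 1 and a 3.6-fold lower number (0.56 log units; beyond the scatter) from compound 2 to compound 4, 5.2-fold (0.72 log units) apart, beyond the scatter of two such steps

For the compounds shown here, with only two cores, this does not show how the size of the step depends on the core, or whether even the direction would hold on a third core. The compounds shown leave open what an amine, a carboxylic acid or a longer chain such as ethoxy would do in place of the bromo. They also leave open what would follow if the methyl on the core gave way to another group.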